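This account rests on a few compounds, and the source may have more. Where it says the series, first, only, none or still open, it means among the compounds named here.

Of the compounds shown here, three have been tested in a functional assay on L1210 cells (Mus musculus) for inhibition; a higher number here means a weaker inhibitor, a lower number a stronger inhibitor. In this test compound 1 `O=C1/C(=C/c2ccc(Br)cc2)CCc2ccccc21` gives 202000 nM, compound 2 `O=C1CCCCC/C1=C\c1ccc(Cl)cc1` gives 83000 nM, and compound 3 `O=C1CCCCC/C1=C\c1cccc(Br)c1` gives 246000 nM. Compound 2 has the lowest number of the three, which makes it the strongest inhibitor so far, and its gaps to the other two lie beyond the usual scatter of repeated measurements.

Compound 4 `CN(C)c1ccc(/C=C2\CCCCCC2=O)cc1` has not yet been measured. It differs from compound 2 in one place: dimethylamino in place of chloro on an aromatic carbon. In words, dimethylamino stands in place of chloro on an aromatic carbon.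

For the measured compounds named here, no two measured compounds differ in just one place, so the data give no direct guide to this swap. Going by the values given here, the only hint is that compound 2, at 83000 nM, sits at the low end of the measured values, so a move toward a higher number seems more likely than a move lower. The expected change is small, a 1.6-fold higher number from compound 2 to compound 4 (0.19 log units; within the scatter), and may stay within the scatter. For compound 4 the estimate is 130000 nM, with an expected range from 45000 nM to 350000 nM.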

Compound 4, half-maximal inhibitory concentration: 79100 nM
Compound 4: middle estimate off by 1.6-fold (0.22 log units), on the high side, within the range that was stated.
By their numbers in this assay, from the lowest: compounds 4 and 2 (each within the scatter of the next); then compounds 1 and 3 (each within the scatter of the next).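

In this assay, the swap of chloro for dimethylamino on this aromatic carbon gives a 1.0-fold lower number from compound 2 to compound 4 (0.02 log units; within the scatter), so the two compounds cannot be told apart. For the compounds shown here, this is the first direct one-place comparison in the set, and it shows that this position can hold a group of 3 heavy atoms, including a nitrogen and a hydrogen-bond acceptor, in place of a single chlorine without leaving the scatter. No measured property of either group is available to account for this result.

On these data alone, whether the same holds for other groups at this position, such as a hydroxyl, a carboxylic acid or a longer alkyl chain, remains open. As far as these compounds go, it is also open whether dimethylamino would give a similar result on the core of compound 1.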